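The source may hold more compounds than are shown below. What is called first, only, known or untested is meant among the compounds shown, and "the series" means these compounds.

In a functional assay on MCF7 cells (Homo sapiens) for cytotoxicity, read by MTT assay, with a stated time of 72 h (a higher number here means a weaker inhibitor, a lower number a stronger inhibitor), compound 1 `CC(C)=C1C(=O)N(c2ccc(Cl)cc2)N(c2ccc(Cl)cc2)C1=O` gives 39600 nM. Compound 2 `O=C1C(=Cc2ccc(Br)cc2)C(=O)N(c2ccc(Cl)cc2)N1c1ccc(Cl)cc1` gives 30400 nM, and these two values lie within the scatter of each other, so neither can be ranked over the other. Compound 3 `COc1ccc(C=C2C(=O)N(c3ccc(Cl)cc3)N(c3ccc(Cl)cc3)C2=O)cc1` gives > 128000 nM, which is a limit of the assay and not a number. For the measured compounds named here, the only measured single-place step is methoxy in place of bromo on an aromatic carbon, and it amounts to an at least 4.2-fold higher number from compound 2 to compound 3 (0.62 log units; beyond the scatter).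

Compound 4 `CC(=C1C(=O)N(c2ccc(Cl)cc2)N(c2ccc(Cl)cc2)C1=O)c1ccc(O)cc1` is compound 1 with 4-hydroxyphenyl in place of methyl on a double-bonded chain carbon bound to a double-bonded ring carbon and a saturated chain carbon. Going by the values given here, no measured step makes this exact change, so the evidence is indirect. Compound 2 also carries an aromatic ring on its double-bonded chain carbon and gives 30400 nM, which suggests that adding a ring need not shift the number much. The oxygen-bearing methoxy group in an at least 4.2-fold higher number from compound 2 to compound 3 (0.62 log units; beyond the scatter) points instead towards a higher number. Weighing the two, the expected change is slightly upward and not beyond the scatter, estimated as a 1.3-fold higher number from compound 1 to compound 4 (0.10 log units; within the scatter). For compound 4 the estimated value is 50000 nM, with an expected range from 15000 nM to 128000 nM.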

Compound 4, half-maximal inhibitory concentration: 76500 nM
Beside the measured number, compound 4's estimate is 1.5-fold (0.18 log units) below it, within the range that was stated.
By their numbers in this assay, from the lowest: compounds 2, 1 and 4 (each within the scatter of the next, the first and the last beyond it). At a limit, above all of these: compound 3.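

Placing 4-hydroxyphenyl in place of methyl on a double-bonded chain carbon bound to a double-bonded ring carbon and a saturated chain carbon gives a 1.9-fold higher number from compound 1 to compound 4 (0.29 log units; within the scatter) in this assay. The step brings in an aromatic ring, a hydrogen-bond donor and a hydrogen-bond acceptor, yet the measured result cannot be told apart from that of compound 1, so this position takes a much larger group without a readable shift in the number. The earlier compounds offered no measured step at this carbon, and compound 4 gives a true number, while compound 3 remains the only compound that gives a limit, which is not a number: the limit of > 128000 nM in this assay, at which 1 of the 4 values shown sits.

The compounds shown leave open what the hydroxyl group contributes on its own, since a plain phenyl at this carbon would be needed to separate it from the ring that carries it. Also open, from the compounds shown here alone, is whether an amine or a carboxylic acid in place of that hydroxyl, or a longer chain such as propyl in place of the methyl, would move the number beyond the scatter.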